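The source may report more compounds than this note shows. Statements on the series, on what has been measured and on what is new or still open speak of the compounds shown alone.

Measured compounds:
- compound 1 `C[C@H]1[C@H](NCc2cncs2)C[C@H]2C[C@@H]1C2(C)C` — in an ADME assay on MDCK cells (Canis lupus familiaris) for cytotoxicity, read by microscopy, with a stated time of 48 h (on this read-out higher numbers stand for lower toxicity in this test and lower numbers for higher toxicity in this test), compound 1 gives > 100000 nM, which is a limit of the assay and not a number.
- compound 2 `C[C@H]1[C@H](NCc2ccc(Br)s2)C[C@H]2C[C@@H]1C2(C)C` — compound 2 gives 43000 nM.
- compound 3 `C[C@H]1[C@H](NCc2cc(-c3ccccc3)cs2)C[C@H]2C[C@@H]1C2(C)C` — compound 3 gives 5000 nM.

Compound 3 stands at the lowest of the two numbers shown; the nearest is compound 2, whose value sits well beyond the scatter above it. Compound 1 sits at the limit (the limit of > 100000 nM in this assay, at which 1 of the 3 values shown sits), so it contributes no number for comparison.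

Among the compounds with values here, the one measured step, an at least 2.3-fold lower number from compound 1 to compound 2 (0.36 log units; beyond the scatter), exchanges one five-membered heteroaryl for another at the saturated carbon bound to the amine nitrogen; it concerns a different position and a different kind of group than the change now at hand. Compounds 2 and 3 differ in more than one place, so their two values only show that the phenyl-bearing member carries the lower number.

Compound 4 `Cc1csc(CN[C@@H]2C[C@H]3C[C@@H]([C@H]2C)C3(C)C)c1` differs from compound 3 by methyl in place of phenyl on an aromatic carbon. Within the data shown here, with no measured step covering this change, the expectation rests on the gap between compound 2 and compound 3: removing the phenyl is expected to move the number back up, giving an estimated 5.0-fold higher number from compound 3 to compound 4 (0.70 log units; beyond the scatter). Compound 4 is therefore expected to give about 25000 nM, with a range from 8000 nM to 80000 nM.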

Compound 4, minimum cytotoxic concentration: 12500 nM
Compound 4: the middle estimate sits 2.0-fold (0.30 log units) above what was measured, within the range that was stated.
By their numbers in this assay, from the lowest: compound 3; then compound 4; then compound 2. At a limit, above all of these: compound 1.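

In this assay, within the data shown here, the exchange on the aromatic carbon two ring bonds from the ring sulfur gives a 2.5-fold higher number from compound 3 to compound 4 (0.40 log units; beyond the scatter), the first measured step at this position, and it ties the phenyl to the lower number with the thiophene and the shared core unchanged. Losing the phenyl does not bring the series back to the level of the bromo member, however: the exchange of 5-bromothiophen-2-yl for 4-methylthiophen-2-yl gives a 3.4-fold lower number from compound 2 to compound 4 (0.54 log units; beyond the scatter), so a methyl on this carbon still leaves the number beyond the scatter on the lower side. The exchange of 1,3-thiazol-5-yl for 4-methylthiophen-2-yl gives an at least 8.0-fold lower number from compound 1 to compound 4 (0.90 log units; beyond the scatter), which is only a bound, with compound 1 standing at a limit of the assay and not at a number: the limit of > 100000 nM in this assay, at which 1 of the 4 values shown sits.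

On these data alone, whether the lower number follows the aromatic ring of the phenyl or only the larger group stays open, and a cyclohexyl or a longer alkyl chain on the same aromatic carbon would separate the two. Also open, as far as these compounds go, is how the read-out behaves with plain hydrogen, an amine or a carboxylic acid on that carbon.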